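Extending methyl to ethyl on the thiadiazole of compound 3

A few compounds are considered here, and "the series" means these few. Any claim that something is new, unique, unknown or untested is made for them only; others in the source may bear on it.

Compound 1: `CCc1nnsc1CO/N=C/c1c(C)nn(C)c1Oc1ccccc1Cl` — 17600 nM
Compound 2: `CCc1nnsc1CO/N=C/c1c(C)nn(C)c1Oc1ccc(C)cc1` — > 50000 nM
Compound 3: `Cc1nnsc1CO/N=C/c1c(C)nn(C)c1Cl` — > 50000 nM

Of the compounds shown here, three sharing the oxime-linked core have been measured in a functional assay on HCT-116 cells (Homo sapiens) for inhibition, read by MTT assay, with a stated time of 48 h; on this read-out higher numbers stand for weaker inhibition and lower numbers for stronger inhibition. Compound 1 gives 17600 nM. Compound 2 returns only a limit of the assay, > 50000 nM. Within the data shown here, the one change between them, an at least 2.8-fold higher number from compound 1 to compound 2 (0.45 log units; beyond the scatter), is the only step that separates two measured compounds. Compound 3 also sits at a limit of the assay, > 50000 nM, so for compound 3 no number is known, only that it stands at the limit of > 50000 nM in this assay, at which 2 of the 3 values shown sit.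

Compound 4, `CCc1nnsc1CO/N=C/c1c(C)nn(C)c1Cl`, differs from compound 3 by methyl in place of hydrogen on a saturated chain carbon bound to an aromatic carbon. Among the measured compounds shown here, no measured step bears on this change: the step from compound 1 to compound 2 alters the group on the oxygen, not the chain on the thiadiazole, and compound 3 differs from compound 1 and compound 2 in two places at once. With nothing in the measured steps pointing either way, the estimated step of a number no higher from compound 3 to compound 4 (the limit leaves the size open) is expected to lie within the scatter. Compound 4 is therefore expected to give about 50000 nM in this assay, with a range from 20000 nM to 120000 nM, most likely reported again as a limit.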

Compound 4, half-maximal inhibitory concentration: > 50000 nM
Compound 4 was reported as a limit; the forecaster's own chance of this, stated with the estimate: 70%; the middle value lies on the limit itself.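

Methyl to ethyl on a saturated chain carbon bound to an aromatic carbon does not bring compound 4 to a number in this assay, so this change shows no readable effect on the chloro compound, and the steps to compound 4 from compound 3 and from compound 2 cannot be read, with limits at both ends. Among these compounds, the result does give a second readable step, at the other place of change: with the ethyl held fixed, chloro in place of 2-chlorophenoxy on an aromatic carbon gives an at least 2.8-fold higher number from compound 1 to compound 4 (0.45 log units; beyond the scatter), so of the two ethyl compounds compared here the 2-chlorophenoxy one is the one that gives a number. Compound 4 itself is a limit, and it adds to the values that rest there: the limit of > 50000 nM in this assay, at which 3 of the 4 values shown sit.

As far as these compounds go, whether methyl and ethyl differ at all on a compound that gives a number in this assay stays open, as does the outcome of a propyl chain at the same place or of an amine or a carboxylic acid in place of the chloro. Equally open, from the compounds shown here alone, is whether plain phenoxy would stand with 2-chlorophenoxy or with 4-methylphenoxy.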